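Hydroxy in place of ethyl on the aromatic carbon

The compounds below may be only part of what the source reports. "The series", "measured", "known", "first", "only" and "open" are said of these compounds alone.

In an assay for inhibition of Dihydrofolate reductase (Bos taurus), at pH 6.25 (a higher number here means a more potent compound, by a factor of ten per unit of this negative logarithm, a lower number a less potent compound), compound 1 `CC1(C)N=C(N)N=C(N)N1c1ccccc1S` gives 7.2, compound 2 `CC1(C)N=C(N)N=C(N)N1c1ccccc1F` gives 4.86, and compound 3 `CCc1ccccc1N1C(N)=NC(N)=NC1(C)C` gives 4.02, the lowest of the three: a number 0.84 log units lower from compound 2 to compound 3 (beyond the scatter) and a number 3.18 log units lower from compound 1 to compound 3 (beyond the scatter). Compound 4 `CC1(C)N=C(N)N=C(N)N1c1ccccc1O` carries the change (hydroxy in place of ethyl on an aromatic carbon). Both measured steps that bear on this one run toward ethyl and both fall, one modestly, one by a large margin; the reverse direction, ethyl replaced by a single-heavy-atom group, should therefore point upward in this assay, with a size somewhere in the span of those two steps. Nothing measured shows whether hydroxy behaves more like fluoro or more like sulfanyl, so the range is wide. Compound 4 is expected at 5.5, within 4.5 to 6.8, an estimated step of a number 1.48 log units higher from compound 3 to compound 4 (beyond the scatter).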

Compound 4, logarithm of the reciprocal of the active concentration, log(1/C): 3.86
Beside the measured number, compound 4's estimate is 1.64 log units above it, outside the stated range (below it).
By their numbers in this assay, from the lowest: compounds 4 and 3 (each within the scatter of the next); then compound 2; then compound 1.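

In this assay, hydroxy and ethyl cannot be told apart at this position (a number 0.16 log units lower from compound 3 to compound 4 (within the scatter)). Hydroxy also falls short of fluoro (a number 1.00 log units lower from compound 2 to compound 4 (beyond the scatter)) and far short of sulfanyl (a number 3.34 log units lower from compound 1 to compound 4 (beyond the scatter)). The large loss on leaving sulfanyl is therefore not specific to ethyl, and a hydrogen-bond donor and acceptor in the entering group does not restore the number of compound 1. Going by these compounds, whether an amine or a methylsulfanyl group on this aromatic carbon would keep any of that number stays open. No available evidence bears on why sulfanyl stands apart from hydroxy.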